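Replacing 4-methylpiperazin-1-yl with an open chain

A few compounds are considered here, and "the series" means these few. Any claim that something is new, unique, unknown or untested is made for them only; others in the source may bear on it.

compound 1 `CCNC(=O)c1nnn(-c2cc(C(C)C)c(O)cc2O)c1-c1ccc(CN2CCCC(O)C2)cc1`: 62 nM
compound 2 `CCNC(=O)c1nnn(-c2cc(C(C)C)c(O)cc2O)c1-c1ccc(CN(CC)CC)cc1`: 11 nM
compound 3 `CCNC(=O)c1nnn(-c2cc(C(C)C)c(O)cc2O)c1-c1ccc(CN2CCN(C)CC2)cc1`: 47 nM

These three compounds keep the shared core and differ only in the group on a saturated chain carbon bound to an aromatic carbon. In a functional assay on NCI-H460 cells (Homo sapiens) for inhibition, read by sulforhodamine B assay, with a stated time of 72 h (on this read-out lower numbers stand for stronger inhibition and higher numbers for weaker inhibition), compound 3 gives 47 nM, and compound 1 gives 62 nM. These two cannot be told apart, the measured gap being a 1.3-fold lower number from compound 1 to compound 3 (0.12 log units; within the scatter). Compound 2 stands clearly apart at 11 nM. Its separation from the other two shows as a 4.3-fold higher number from compound 2 to compound 3 (0.63 log units; beyond the scatter) and as a 5.6-fold lower number from compound 1 to compound 2 (0.75 log units; beyond the scatter).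

The next compound is compound 4 `CCNC(=O)c1nnn(-c2cc(C(C)C)c(O)cc2O)c1-c1ccc(CNCCCN(CC)CC)cc1`. It carries (3-(diethylamino)propyl)amino in place of 4-methylpiperazin-1-yl on a saturated chain carbon bound to an aromatic carbon. Among the compounds with values here, no measured step covers such a chain. The nearest guide is compound 2 at 11 nM, which also carries diethylamino and has no ring in this group, although its diethylamino is attached directly to the chain carbon. Only part of that modest gap is therefore expected to carry over, so a small move toward lower numbers in this assay is anticipated, not clearly beyond the scatter. The expected change is a 1.7-fold lower number from compound 3 to compound 4 (0.22 log units; within the scatter). Compound 4 is estimated at 28 nM, with an expected range from 9 nM to 85 nM.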

Compound 4, half-maximal inhibitory concentration: 412 nM
Beside the measured number, compound 4's estimate is 15-fold (1.17 log units) below it, and the stated range ends below it.
By their numbers in this assay, from the lowest: compound 2; then compounds 3 and 1 (each within the scatter of the next); then compound 4.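

In this assay, the open chain of compound 4 stands apart from all three earlier groups, with an 8.8-fold higher number from compound 3 to compound 4 (0.94 log units; beyond the scatter), a 6.6-fold higher number from compound 1 to compound 4 (0.82 log units; beyond the scatter) and a 37-fold higher number from compound 2 to compound 4 (1.57 log units; beyond the scatter). Within the data shown here, the earlier compounds held only one open group at this place, diethylamino, and it gave the lowest number; compound 4 shows that having no ring does not by itself go with a low number here, as compound 2 and compound 4 both lack a ring yet sit at opposite ends of the series. Among these compounds, nothing available bears on why (3-(diethylamino)propyl)amino raises the number so far.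

The propyl chain and its added amino hydrogen enter together, and the compounds shown cannot separate what each contributes. Still open, from the compounds shown here alone, is how a shorter (2-(diethylamino)ethyl)amino chain, a longer (4-(diethylamino)butyl)amino chain, or a version with a methyl group on the amino nitrogen attached to the saturated chain carbon would read, and whether any of them would move back toward compound 2.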